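A few compounds are considered here, and "the series" means these few. Any claim that something is new, unique, unknown or untested is made for them only; others in the source may bear on it.

Compound 1 `Fc1ccc(-c2[nH]c3cc(F)ccc3c2Cn2ccnc2)cc1` and compound 2 `Fc1ccc2c(Cn3ccnc3)c(-c3ccc(Cl)cc3)[nH]c2c1` share one core and differ by a single exchange: chloro in place of fluoro on an aromatic carbon. In an assay on isolated protein for inhibition of Aromatase (Homo sapiens), read by ELISA, using NADPH, with a stated time of 24 h (on this read-out lower numbers stand for stronger inhibition and higher numbers for weaker inhibition), compound 1 gives 51.2 nM, while compound 2 gives 82.9 nM, so that this exchange made a 1.6-fold higher number from compound 1 to compound 2 (0.21 log units; within the scatter). Compound 3 `COc1ccc(-c2[nH]c3cc(F)ccc3c2Cn2cncn2)cc1` is built on a different core; how its core differs from that of compound 1 is not broken down here. In this assay compound 3 gives 14.1 nM, the lowest of the three numbers, with compound 1 nearest and compound 2 furthest from it, both beyond the scatter. Compound 4 `COc1ccc(-c2[nH]c3cc(Cl)ccc3c2Cn2cncn2)cc1` is not yet measured and differs from compound 3 by chloro in place of fluoro on an aromatic carbon. This is the same kind of change as that from compound 1 to compound 2, but not the same: there the place was on a six-membered aromatic ring of carbon only, para to a large group, whereas here it lies on a ring that is part of a fused system of two rings, meta to a fused ring and para to a fused ring. Resting on the earlier step of a 1.6-fold higher number from compound 1 to compound 2 (0.21 log units; within the scatter), compound 4 is expected to show a step of a 1.6-fold higher number from compound 3 to compound 4 (0.19 log units; within the scatter). Compound 4 is therefore estimated at 22 nM, between 10 nM and 50 nM.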

Compound 4, half-maximal inhibitory concentration: 197 nM
The estimate for compound 4 lay 9.0-fold (0.95 log units) below the measured number; measured number above the stated range.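

In this assay, chloro in place of fluoro on an aromatic carbon gave a 14-fold higher number from compound 3 to compound 4 (1.15 log units; beyond the scatter), and this step does not match the earlier one, so the size of the exchange did not carry from one core to the other: the same change on two cores in this assay, a 1.6-fold higher number (0.21 log units; within the scatter) from compound 1 to compound 2 and a 14-fold higher number (1.15 log units; beyond the scatter) from compound 3 to compound 4, 8.6-fold (0.94 log units) apart, beyond the scatter of two such steps. The result shows that, within this series, a step read on one core cannot simply be transferred to another, even when the same two groups are exchanged. It does not show what separates the two steps, since the pairs differ both in the rest of the core and in the place of the exchange, which in the newer pair lies on a ring that is part of a fused system of two rings, and two pairs give no general rule.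

The compounds shown leave open how large the same exchange would be at this place on the core of compound 1. They also leave open how bromo, a nitrile or an amine at this place would read out against fluoro and chloro.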